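Fluoro for Methyl on the Aryl Group of Compound 1

The source may hold more compounds than are shown below. What is called first, only, known or untested is meant among the compounds shown, and "the series" means these compounds.

Compound 1 `Cc1ncccc1N1C[C@]2(CC[C@@H](CNc3cnn(-c4ccccc4F)c3)CC2)OC1=O`: 0.631 nM
Compound 2 `O=C1O[C@]2(CC[C@H](CNc3nc(-c4ccccn4)cs3)CC2)CN1c1ccccn1`: 0.0794 nM

Of the compounds shown here, two have been measured in a functional assay for antagonist activity at Neuropeptide Y receptor type 5 (Homo sapiens); on this read-out higher numbers stand for weaker inhibition and lower numbers for stronger inhibition. Compound 1 stands at the higher of the two numbers, and compound 2 at a lower one, a gap that lies beyond the usual scatter of repeated measurements. For the measured compounds named here, the two differ in more than one place, so no single step between them can be read.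

Compound 3 `O=C1O[C@]2(CC[C@H](CNc3cnn(-c4ccccc4F)c3)CC2)CN1c1cccnc1F` is the compound still to be measured. It keeps the core of compound 1 and differs from it in one place: fluoro in place of methyl on an aromatic carbon. Going by the values given here, no measured pair shows this exchange, so its effect in this assay is not known from the numbers at hand. A change of this kind, one heavy atom for one heavy atom, is expected to move the number little, with the step from compound 1 to compound 3 estimated as a 1.3-fold lower number from compound 1 to compound 3 (0.10 log units; within the scatter), within or close to the scatter. Compound 3 is therefore expected to give about 0.5 nM, with a likely range from 0.15 nM to 1.6 nM.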

Compound 3, inhibition constant: 0.1 nM
For compound 3 the middle estimate is 5.0-fold (0.70 log units) above the measured one, outside the stated range (below it).
By their numbers in this assay, from the lowest: compounds 2 and 3 (each within the scatter of the next); then compound 1.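

In this assay, for the compounds shown here, the exchange of 2-methylpyridin-3-yl for 2-fluoropyridin-3-yl gives a 6.3-fold lower number from compound 1 to compound 3 (0.80 log units; beyond the scatter) and is the first step in this set that can be read. It shows that this position, on an aromatic carbon next to the ring nitrogen and ortho to a large group, responds to the exchange of one heavy atom for another, with fluoro giving the stronger inhibition of the pair. Nothing available here accounts for the size of this step.

The compounds shown leave open whether other groups at this position, such as chloro, methoxy or an amine, would give a number like that of fluoro or that of methyl. They also leave open whether the same exchange would give a similar step with a different side chain on the shared core.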